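Switching the carboxylic acid around the benzyl ring

The compounds below may be only part of what the source reports. "The series", "measured", "known", "first", "only" and "open" are said of these compounds alone.

Of the compounds shown here, two have been tested in an assay on HEK293T cells for agonist activity at Bile acid receptor (Homo sapiens), read by a luciferase reporter and fluorescence; a higher number here means that more compound is needed for the effect, a lower number that less compound is needed. Compound 1 `CC(C)c1snc(-c2c(Cl)cccc2Cl)c1COc1ccc(N(C)Cc2ccc(C(=O)O)cc2)c(C(F)(F)F)n1` gives 350 nM. Compound 2 `CN(Cc1cccc(C(=O)O)c1)c1ccc(OCc2c(-c3c(Cl)cccc3Cl)nsc2C2CC2)nc1C(F)(F)F` gives 270 nM in this assay, which is the lower of the two numbers, though the gap to compound 1 lies within the usual scatter of repeated measurements, so the two cannot be told apart with confidence.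

Compound 3 `CN(Cc1ccc(C(=O)O)cc1)c1ccc(OCc2c(-c3c(Cl)cccc3Cl)nsc2C2CC2)nc1C(F)(F)F` has not yet been measured. It keeps every atom of compound 2 and changes only how they are joined: 4-carboxyphenyl in place of 3-carboxyphenyl on a saturated chain carbon bound to a nitrogen on an aromatic ring. Going by the values given here, no measured pair shows this exact change on this core, so the expected size of the step is uncertain. Compound 1, which also carries the 4-carboxyphenyl, sits close to compound 2, which suggests no step beyond the scatter. The estimated step from compound 2 to compound 3 is a 1.1-fold higher number from compound 2 to compound 3 (0.05 log units; within the scatter). Compound 3 is therefore expected to give about 300 nM in this assay, with a plausible range from 120 nM to 750 nM.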

Compound 3, half-maximal effective concentration: 310 nM
Compound 3: the middle estimate sits 1.0-fold (0.01 log units) below what was measured, within the range that was stated.
By their numbers in this assay, from the lowest: compounds 2, 3 and 1 (each within the scatter of the next).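

In this assay, going by these compounds alone, the change from 3-carboxyphenyl to 4-carboxyphenyl on a saturated chain carbon bound to a nitrogen on an aromatic ring gives a 1.1-fold higher number from compound 2 to compound 3 (0.06 log units; within the scatter) and is the first direct reading of this change on this core. At this level of resolution, the two placements of the carboxylic acid cannot be told apart. Compound 3 also allows a second reading, cyclopropyl in place of isopropyl on an aromatic carbon, which gives a 1.1-fold lower number from compound 1 to compound 3 (0.05 log units; within the scatter) and likewise shows no separable effect, and no measurement at hand explains either result.

Still open, as far as these compounds go, is whether the carboxylic acid can be replaced on this ring, for example by an amide or a tetrazole, with a step beyond the scatter. From the compounds shown here alone, it is equally open whether a larger group than cyclopropyl or isopropyl on that aromatic carbon, such as tert-butyl, would change the number.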